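Thiophene for Phenyl on a Cyclic Amidine Series

A few compounds are considered here, and "the series" means these few. Any claim that something is new, unique, unknown or untested is made for them only; others in the source may bear on it.

Measured compounds in a functional assay on the whole organism (plasma, strain Sprague-Dawley) with Rattus norvegicus as the target, with a stated time of 2 h, at a dose of 12.5 mg/kg by the oral route; on this read-out higher numbers stand for a stronger effect at the one dose given and lower numbers for a weaker effect:
Compound 1, `c1ccc(C(/N=C2\CCCCCN2)C2CC2)cc1`, gives 5%.
Compound 2, `COc1ccc(C(/N=C2\CCCCCN2)C2CC2)cc1`, gives 1%.
Compound 3, `c1ccc(C(/N=C2\CCCCCN2)C2CCCC2)cc1`, gives 12%.

Compound 1 sits between the other two numbers, and neither gap is meaningful: the step of a number 4 percentage points lower from compound 1 to compound 2 (within the scatter) and the step of a number 7 percentage points higher from compound 1 to compound 3 (within the scatter) both fall inside the scatter of this assay. The three measured compounds therefore describe a flat surface, with no change at either the aromatic carbon or the saturated ring having moved the read-out.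

Compound 4, `c1csc(C(/N=C2\CCCCCN2)C2CC2)c1`, has not yet been measured. It differs from compound 1 in one place: thiophen-2-yl in place of phenyl on a saturated chain carbon bound to a double-bonded nitrogen and a saturated ring carbon. Going by the values given here, no measured step touches this part of the core; the two known steps concern a substituent on the aromatic ring and the size of the saturated ring, and both were within the scatter. Nothing in the data points toward a step in this assay beyond the scatter in either direction, and the level of the whole series is low.

The expectation for compound 4 in this assay is therefore a step of a number 1 percentage points higher from compound 1 to compound 4 (within the scatter), that is no change beyond the scatter. Compound 4 is estimated at 6%, with a range from 0% to 16%.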

Compound 4, a percentage reported as inhibition, in the whole organism at one dose (the size of the read-out at that dose, not a potency): 33%
The estimate for compound 4 lay 27 percentage points below the measured number; the whole stated range lies below it.
By their numbers in this assay, from the lowest: compounds 2, 1 and 3 (each within the scatter of the next, the first and the last beyond it); then compound 4.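

In this assay, going by these compounds alone, the aromatic group on a saturated chain carbon bound to a double-bonded nitrogen and a saturated ring carbon is the first place where a single change moves the read-out beyond the scatter, with thiophen-2-yl in place of phenyl giving a number 28 percentage points higher from compound 1 to compound 4 (beyond the scatter) at this one dose. The flat picture left by the methoxy and cyclopentyl changes therefore does not extend to replacing the phenyl itself, although the step is a modest one. The change alters the ring size and brings in sulfur at the same time, the data do not separate the two, and no evidence is available on why the read-out moved.

The compounds shown leave open whether a furyl or a pyridyl group in the same place would give a comparable step, which would help separate the ring size from the sulfur. They also leave open whether the thiophen-2-yl step would hold with cyclopentyl in place of cyclopropyl, and whether it would persist at other doses and times.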